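This account rests on a few compounds, and the source may have more. Where it says the series, first, only, none or still open, it means among the compounds named here.

In a functional assay on CCRF-CEM cells (Homo sapiens) for inhibition, read by cell counting, with a stated time of 3 days (on this read-out higher numbers stand for weaker inhibition and lower numbers for stronger inhibition), compound 2, with the structure `C=C(Br)C(=O)Nc1cccc(-c2cn3nc(Cc4ccc(OC)cc4)sc3n2)c1`, gives 2300 nM. Among the measured compounds shown here, this is the only number reported in this assay; the one other value shown is a limit. Compound 1, with the structure `Nc1cccc(-c2cn3nc(-c4ccc(F)cc4)sc3n2)c1`, returns only a limit in this assay, at >= 250000 nM, and the evidence on that point is the limit of >= 250000 nM in this assay, at which 1 of the 2 values shown sits. Compound 1 carries an aniline where compound 2 carries the bromoacrylamide, and it also differs in the group on the core, so the two cannot be compared as a single step. Compound 3, with the structure `C=C(Br)C(=O)Nc1cccc(-c2cn3nc(-c4ccc(OC)cc4)sc3n2)c1`, has not yet been measured in this assay. It differs from compound 2 in one place: 4-methoxyphenyl in place of 4-methoxybenzyl on an aromatic carbon. For the measured compounds named here, with no measured step of this kind to lean on, the expected change from compound 2 to compound 3 in this assay is modest and may well fall within the usual scatter, with no firm direction. On that basis compound 3 is estimated at 3000 nM, with a range from 800 nM to 12000 nM. The estimated step is a 1.3-fold higher number from compound 2 to compound 3 (0.12 log units; within the scatter).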

Compound 3, half-maximal inhibitory concentration: 1200 nM
Compound 3: middle estimate off by 2.5-fold (0.40 log units), on the high side, within the range that was stated.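

Among the compounds shown here, with the 4-methoxyphenyl in place of the 4-methoxybenzyl on this aromatic carbon of the five-membered ring, this assay gives the first step that can be read at this position, and it is a 1.9-fold lower number from compound 2 to compound 3 (0.28 log units; within the scatter). The earlier compounds shown here offered no such comparison, and this one shows that on this read-out the two groups, which differ by the benzyl carbon, cannot be told apart, so the ring here can sit directly on the core or one carbon away from it with the result staying within the scatter. The compounds shown give no reason for this step, and with a change inside the scatter there is none to explain.

On these data alone, what the bromoacrylamide itself contributes stays open, as compound 1, which has an aniline there and also a different group on the core, gives only a limit of >= 250000 nM and is joined to neither compound by a single step. Also open, as far as these compounds go, is how this position would respond to a longer chain such as 2-(4-methoxyphenyl)ethyl, or to an amine such as morpholine in place of the aromatic ring.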